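A few compounds are considered here, and "the series" means these few. Any claim that something is new, unique, unknown or untested is made for them only; others in the source may bear on it.

Measured compounds in an ADME assay on MT2 cells (Homo sapiens) for cytotoxicity, read by MTT assay; a lower number here means that less compound is tolerated, a higher number that more compound is tolerated:

compound 1 `N#Cc1cc2c(Oc3ccc(F)cc3OCCn3ccc(=O)[nH]c3=O)cccc2o1`, which gives > 100000 nM, a limit of the assay.
compound 2 `N#Cc1ccc2c(Oc3ccc(F)cc3OCCn3ccc(=O)[nH]c3=O)cccc2c1`, which gives > 100000 nM, a limit of the assay.
compound 3 `N#Cc1cc2c(Oc3ccccc3OCCn3ccc(=O)[nH]c3=O)cccc2o1`, which gives > 100000 nM, a limit of the assay.

Compound 3 differs from compound 1 by hydrogen in place of fluoro on an aromatic carbon. The resulting step is a step that the two limits leave unreadable from compound 1 to compound 3. The difference between the cores of compound 1 and compound 2 is not broken down here.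

Compound 4 `N#Cc1ccc2c(Oc3ccccc3OCCn3ccc(=O)[nH]c3=O)cccc2c1` is not yet measured in this assay. It differs from compound 2 by hydrogen in place of fluoro on an aromatic carbon, the same change as from compound 1 to compound 3. For this assay the step from compound 2 to compound 4 is expected to be a step that the limit leaves unreadable from compound 2 to compound 4, beside the earlier step, resting on (the limit of > 100000 nM in this assay, at which 3 of the 3 values shown sit). Compound 4 is accordingly expected to give 150000 nM, between 60000 nM and 400000 nM.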

Compound 4, half-maximal cytotoxic concentration: > 100000 nM
Compound 4: no number, only a limit (the forecaster's own chance of this, stated with the estimate: 85%); the middle value lies beyond the limit too.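

No step can be read from compound 2 to compound 4, as both values are limits of the assay: the limit of > 100000 nM in this assay, at which 4 of the 4 values shown sit.

The compounds shown leave open where any of them lies beyond that limit, and so whether exchanging fluoro for hydrogen or changing the core alters the result.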